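A Larger Aryl Group on a Sulfonyl Sulfur

The source may hold more compounds than are shown below. What is called first, only, known or untested is meant among the compounds shown, and "the series" means these compounds.

In a functional assay on LNCaP cells (Homo sapiens) for antiproliferative activity, read by propidium iodide staining, with a stated time of 96 h (a lower number here means a stronger inhibitor, a higher number a weaker inhibitor), compound 1 `CC(O)(CSc1ccccc1C(F)(F)F)C(=O)Nc1ccc(S(F)(F)(F)(F)F)cc1` gives 12300 nM, and compound 2 `CC(O)(COc1cccc(OC(F)(F)F)c1)C(=O)Nc1cccc(S(F)(F)(F)(F)F)c1` gives 15200 nM. Compound 3 `CC(O)(CS(=O)(=O)c1ccc(F)cc1)C(=O)Nc1cccc(S(F)(F)(F)(F)F)c1` gives 32600 nM, the highest of the three numbers, and its gaps to both others lie beyond the scatter. That makes compound 3 the weakest inhibitor measured so far.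

Compound 4 `CC(O)(CS(=O)(=O)c1ccccc1OC(F)(F)F)C(=O)Nc1cccc(S(F)(F)(F)(F)F)c1` has not yet been measured. It carries 2-(trifluoromethoxy)phenyl in place of 4-fluorophenyl on a sulfonyl sulfur. Within the data shown here, no two measured compounds differ in one place only, so the data offer no direct guide to this change. The only hint is loose: compound 2 also carries a trifluoromethoxy group and gives 15200 nM. A modest fall in the number is therefore expected, pointing to a somewhat stronger inhibitor, though the step may barely clear the scatter. The estimated step runs a 1.8-fold lower number from compound 3 to compound 4 (0.26 log units; within the scatter). For compound 4 the estimated value is 18000 nM, with an expected range from 8000 nM to 40000 nM.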

Compound 4, half-maximal inhibitory concentration: 9000 nM
Compound 4: middle estimate off by 2.0-fold (0.30 log units), on the high side; low and high end bracket the measured number.
By their numbers in this assay, from the lowest: compounds 4, 1 and 2 (each within the scatter of the next); then compound 3.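

Among these compounds, on a sulfonyl sulfur, the aryl group clearly matters: in this assay, placing 2-(trifluoromethoxy)phenyl where 4-fluorophenyl stood gives a 3.6-fold lower number from compound 3 to compound 4 (0.56 log units; beyond the scatter), the only single-place comparison in this set. The position therefore accepts a group of 11 heavy atoms in place of one of 7, and here the larger group goes with a stronger inhibitor. No further data bear on why the number falls.

This single step cannot show whether the gain follows the trifluoromethoxy group itself or where it sits on the ring, since the fluorine of 4-fluorophenyl leaves in the same change. From the compounds shown here alone, how plain phenyl, 4-(trifluoromethoxy)phenyl or a non-aromatic group such as cyclohexyl would read on the same sulfur remains open.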